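The source may report more compounds than this note shows. Statements on the series, on what has been measured and on what is new or still open speak of the compounds shown alone.

Measured so far:
- compound 1, `CCCCN(CC)c1nc(C)nc2c1NC(=O)CN2c1ccc(OC)cc1C`: 95 nM
- compound 2, `CCCCN(CC)c1cc(C)nc2c1NCCN2c1ccc(C#N)cc1C`: 3.5 nM

Compound 1 gives the higher of the two numbers in an assay on frontal cortex for displacement of a labelled ligand from corticotropin-releasing factor receptor 1 (Rattus norvegicus); on this read-out lower numbers stand for stronger inhibition and higher numbers for weaker inhibition; compound 2, which differs from it at several points, gives 3.5 nM, a much lower number that lies well beyond the scatter. For the measured compounds named here, no single-change step between measured compounds is available, so the two values show only that the cyano-bearing compound 2 binds far more strongly than compound 1.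

Compound 3, `CCCCN(CC)c1nc(C)nc2c1NC(=O)CN2c1ccc(C#N)cc1C`, keeps the core of compound 1 and changes one thing: cyano in place of methoxy on an aromatic carbon. Compound 3 thus carries the same cyano group as compound 2, though on the core of compound 1. Whether the change alone accounts for any of the gap between compound 1 and compound 2 is not known from these data.

The step of a 2.4-fold lower number from compound 1 to compound 3 (0.38 log units; beyond the scatter) is expected to be a modest one towards a lower number, possibly no larger than the scatter. Compound 3 is accordingly estimated at 40 nM in this assay, within a range of 12 nM to 130 nM.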

Compound 3, half-maximal inhibitory concentration: 573 nM
Beside the measured number, compound 3's estimate is 14-fold (1.16 log units) below it, outside the stated range (above it).
By their numbers in this assay, from the lowest: compound 2; then compound 1; then compound 3.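

On the core of compound 1, going from 4-methoxy-2-methylphenyl to 4-cyano-2-methylphenyl gives a 6.0-fold higher number from compound 1 to compound 3 (0.78 log units; beyond the scatter) in this assay and so, at this place on the aromatic ring, para to a large group and meta to a methyl group, cyano goes with weaker inhibition than methoxy on this core. The earlier pair differed at several points and could not isolate this change, and this single step now shows that cyano does not lower the number on the core of compound 1, even though the cyano-bearing compound 2 gives a low one. The compounds shown offer no measurement that would explain the step.

As far as these compounds go, compound 2 and compound 3 carry the same substituted aromatic ring but differ in more than one place, so whether the exchange of methoxy for cyano would run the same way on the core of compound 2 remains open. Also open, from the compounds shown here alone, is how other groups at this place on the core of compound 1, such as chloro, an amine or a longer ether chain like ethoxy, would compare with methoxy and cyano.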